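This account rests on a few compounds, and the source may have more. Where it says the series, first, only, none or still open, it means among the compounds named here.

Compound 3 `O/N=C(\CCN1CCN(c2ccccn2)CC1)c1cccc(F)c1` belongs to a small series sharing one core, and in a functional assay on HEK293 cells with D(4) dopamine receptor (Homo sapiens) as the target, read by FLIPR (a higher number here means a larger maximal response, a lower number a smaller maximal response), compound 3 gives 72%. That reading is level with compound 2 `Cc1ccccc1/C(CCN1CCN(c2ccccn2)CC1)=N\O`, which gives 72%, and together they are the lowest of the three numbers; compound 1 `O/N=C(/CCN1CCN(c2ccccn2)CC1)c1ccccc1` gives 74%, a gap that stays within the usual scatter. Within the data shown here, the only measured single step, a number 2 percentage points lower from compound 1 to compound 2 (within the scatter), is a methyl in place of hydrogen on an aromatic carbon, and the values of compound 1 and compound 3 show a similarly small gap. Compound 4 `O/N=C(\CCN1CCN(c2ccccn2)CC1)c1ccc(Cl)cc1` differs from compound 3 by 4-chlorophenyl in place of 3-fluorophenyl on a carbon with a double bond to nitrogen. The expected step of no change at the digits printed from compound 3 to compound 4 (within the scatter) is none beyond the scatter. Compound 4 is estimated at 72%, with a range from 60% to 83%.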

Compound 4, largest response reached (reported as efficacy), in percent of the reference or control that the assay uses: 46%
Estimate against measurement, compound 4: 26 percentage points above; measured number outside the range, below it.
By their numbers in this assay, from the lowest: compound 4; then compounds 2, 3 and 1 (each within the scatter of the next).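

In this assay, swapping 4-chlorophenyl for 3-fluorophenyl on the carbon with a double bond to nitrogen gives the only step shown that lies beyond the scatter: a number 26 percentage points lower from compound 3 to compound 4 (beyond the scatter). The maximal response at this position therefore depends on which aryl group sits there, even though both groups have the same ring and the same heavy-atom count. Nothing available explains the drop. This swap changes both the halogen and its place on the ring, so the two effects cannot be separated. Either 3-chlorophenyl or 4-fluorophenyl would change only one of them.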